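The source may report more compounds than this note shows. Statements on the series, on what has been measured and on what is new or still open speak of the compounds shown alone.

Two compounds have been measured in a functional assay on cells (Splenocyte, Mus musculus, strain BALB/c) for inhibition, read by scintillation counting and thymidine incorporation, with a stated time of 72 h; a lower number here means a stronger inhibitor, a higher number a weaker inhibitor:
compound 1 `CC(/C=N/Nc1ccc([N+](=O)[O-])cc1)=N\NC(=O)c1ccccc1O`, which gives 1640 nM;
compound 2 `CC(/C=N/Nc1ccc([N+](=O)[O-])cc1)=N\NC(=O)c1ccccc1C`, which gives 6000 nM.

Among the measured compounds shown here, compound 2 stands highest of the two numbers; its nearest neighbour is compound 1, and the only step recorded, a 3.7-fold higher number from compound 1 to compound 2 (0.56 log units; beyond the scatter), separates them. Compound 3 `CC(/C=N/Nc1ccc([N+](=O)[O-])cc1)=N\NC(=O)c1ccccc1Oc1ccccc1` differs from compound 2 in one place: phenoxy in place of methyl on an aromatic carbon. For the measured compounds named here, no measured step bears directly on this change; the one step known, from hydroxy to methyl, concerns a different pair of groups and offers no guide to what phenoxy does in this position. With nothing firmer to lean on, the expected step is none beyond the scatter, and compound 3 is estimated to show a 1.2-fold lower number from compound 2 to compound 3 (0.08 log units; within the scatter). On that basis compound 3 is expected to give about 5000 nM in this assay, within a range from 1500 nM to 20000 nM.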

Compound 3, half-maximal inhibitory concentration: > 12000 nM
Compound 3 gave a limit, no number (the forecaster's own chance of this, stated with the estimate: 10%); middle value at least 2.4-fold (0.38 log units) from the limit.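

Compound 3 gives no number in this assay, only a limit: the limit of > 12000 nM in this assay, at which 1 of the 3 values shown sits.

The change to phenoxy gives an at least 2.0-fold higher number from compound 2 to compound 3 (0.30 log units; that floor lies within the scatter), so this position does not yet show a firm difference between the two groups, although the true step may be larger than its floor. Against hydroxy the picture is clearer, with phenyl on the oxygen giving an at least 7.3-fold higher number from compound 1 to compound 3 (0.86 log units; beyond the scatter), which leaves compound 1 the strongest inhibitor of the three, ahead of both methyl and phenoxy at this position.

On these data alone, how far compound 3 lies past its limit remains open, and with it the true size of the step from methyl to phenoxy. Also open, as far as these compounds go, is whether an amine or a methoxy group at this position would stay close to hydroxy or move towards methyl and phenoxy.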